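Moving one hydroxyl on a triaryl pyridine core

This account rests on a few compounds, and the source may have more. Where it says the series, first, only, none or still open, it means among the compounds named here.

Compound 2 `Oc1cccc(-c2cc(-c3ccccc3O)nc(-c3ccccc3O)c2)c1` is one of two measured compounds. In a functional assay on HCT-15 cells (Homo sapiens) for cytotoxicity, read by CCK-8 assay, with a stated time of 4 days (a higher number here means a weaker inhibitor, a lower number a stronger inhibitor), compound 2 gives 5020 nM, and compound 1 `Oc1ccc(-c2cc(-c3cccc(O)c3)nc(-c3cccc(O)c3)c2)cc1` gives 3810 nM; the two numbers lie within the usual scatter of each other, so neither can be called the stronger. Compound 3 `Oc1cccc(-c2cc(-c3cccc(O)c3)nc(-c3ccccc3O)c2)c1` differs from compound 2 by 3-hydroxyphenyl in place of 2-hydroxyphenyl on an aromatic carbon. Among the measured compounds shown here, no step between measured compounds informs this change, so compound 3 is expected to stay close to compound 2, with a step of a 1.1-fold lower number from compound 2 to compound 3 (0.05 log units; within the scatter) of no size beyond the scatter in either direction. Compound 3 is therefore estimated at 4500 nM, with a range from 2200 nM to 9000 nM.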

Compound 3, half-maximal inhibitory concentration: > 50000 nM
Compound 3 ended at the assay's limit; the forecaster's own chance of this, stated with the estimate: 5%; middle value at least 11-fold (1.04 log units) away from the limit.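

Replacing 2-hydroxyphenyl with 3-hydroxyphenyl on the aromatic carbon next to the ring nitrogen leaves the atoms unchanged, yet in this assay it gives an at least 9.9-fold higher number from compound 2 to compound 3 (0.99 log units; beyond the scatter). The value of compound 3, > 50000 nM, is a limit of the assay and not a number: the limit of > 50000 nM in this assay, at which 1 of the 3 values shown sits.

Compound 1 and compound 2 had not shown that moving one hydroxyl at this position can matter so much. On these data alone, it remains open whether a methoxy group or an amine in place of that hydroxyl would keep the activity of compound 2.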